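A Cyclopropane Drawn Without Its Configuration

The compounds below may be only part of what the source reports. "The series", "measured", "known", "first", "only" and "open" are said of these compounds alone.

Compound 1 `CNC(=O)[C@]12C[C@@H]1[C@@H](n1cnc3c(NCc4ccc(N=[N+]=[N-])cc4)nc(C#Cc4ccc(F)c(F)c4)nc31)[C@H](O)[C@@H]2O` gives >= 99 nM in an assay on isolated protein for binding affinity to adenosine receptor A3 (Homo sapiens); a lower number here means a stronger inhibitor, a higher number a weaker inhibitor.
Compound 2 `CNC(=O)[C@]12C[C@@H]1[C@@H](n1cnc3c(N[C@H]4C[C@@H]4c4ccc(F)c(F)c4)nc(C#Cc4cccc(F)c4)nc31)[C@H](O)[C@@H]2O` gives >= 99 nM in this assay.
Compound 3 `CNC(=O)[C@]12C[C@@H]1[C@@H](n1cnc3c(NCc4cccc(Cl)c4)nc(C#Cc4ccc(Cl)s4)nc31)[C@H](O)[C@@H]2O` gives >= 99 nM in this assay.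

Each of these results is a limit of the assay rather than a measured number. For compound 2 the entry is such a limit. Compound 2 therefore stands nowhere in particular on the numbers shown: it sits at the same limit as the other two compounds (the limit of >= 99 nM in this assay, at which 3 of the 3 values shown sit), and nothing in the data separates it from them or ranks it against them.

Compound 4 `CNC(=O)[C@]12C[C@@H]1[C@@H](n1cnc3c(NC4CC4c4ccc(F)c(F)c4)nc(C#Cc4cccc(F)c4)nc31)[C@H](O)[C@@H]2O` is the next compound to be measured. How it differs from compound 2 is counted as the two compounds have the same atoms and bonds; at least one stereo element is drawn with a configuration in one of them and without one in the other: 2 of 7 stereo elements differ; a stereocentre at a saturated ring carbon is drawn S in compound 2 and without a configuration in compound 4; a stereocentre at a saturated ring carbon is drawn R in compound 2 and without a configuration in compound 4. Among the compounds with values here, the atoms and bonds are identical; what changes is only that two ring carbons of the saturated ring carry a drawn configuration in compound 2 and carry none in compound 4.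

Within the data shown here, no step between measured compounds is available to guide an expectation. Because the change leaves atoms and bonds untouched, and compound 2 sits at the limit (the limit of >= 99 nM in this assay, at which 3 of the 3 values shown sit), the step expected from compound 2 to compound 4 is a step that the limit leaves unreadable from compound 2 to compound 4, meaning none beyond the scatter. Compound 4 is therefore expected to come out at about 150 nM, within a range of 60 nM to 1000 nM, most likely again as a limit.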

Compound 4, inhibition constant: >= 99 nM
Compound 4: no number, only a limit; the forecaster's own chance of this, stated with the estimate: 75%; the middle value is on the limit's open side.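

In this assay compound 4 gives >= 99 nM, which is a limit of the assay and not a number. Compound 2 also has only a limit, so no step can be read between compound 2 and compound 4. The compounds shown leave open whether the configuration drawn at the two ring carbons affects the result, and how all four compounds rank: the limit of >= 99 nM in this assay, at which 4 of the 4 values shown sit.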